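Fluorine isomer swap on the pyridine of compound 3

The compounds below may be only part of what the source reports. "The series", "measured", "known", "first", "only" and "open" are said of these compounds alone.

In a functional assay on KYSE-410 cells (Homo sapiens) for antiproliferative activity, read by MTT assay, with a stated time of 72 h (on this read-out lower numbers stand for stronger inhibition and higher numbers for weaker inhibition), compound 1 `O=C(Nc1cccc(F)c1)c1cc(=O)[nH]c2cc(Br)ccc12` gives 7300 nM and compound 2 `O=C(Nc1cccc(F)c1)c1cc(=O)[nH]c2cc(-c3cccc(F)c3)ccc12` gives 10900 nM (with a 1.5-fold higher number from compound 1 to compound 2 (0.17 log units; within the scatter)). Compound 3 `O=C(Nc1cccc(F)c1)c1cc(=O)[nH]c2cc(-c3ccc(F)nc3)ccc12` reads > 20000 nM as a limit of the assay and not a number. Compound 4 `O=C(Nc1cccc(F)c1)c1cc(=O)[nH]c2cc(-c3cccnc3F)ccc12` differs from compound 3 by 2-fluoropyridin-3-yl in place of 6-fluoropyridin-3-yl on an aromatic carbon. The steps bearing on this change are an at least 2.7-fold higher number from compound 1 to compound 3 (0.43 log units; beyond the scatter) and an at least 1.8-fold higher number from compound 2 to compound 3 (0.26 log units; that floor lies within the scatter) (each only a floor). Neither covers this exchange directly, so no step beyond the scatter is expected in either direction. The step expected is an at least 1.1-fold lower number from compound 3 to compound 4 (0.07 log units; that floor lies within the scatter) on this estimate. In this assay compound 4 is expected at 17000 nM (estimated range 8000 nM to 35000 nM).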

Compound 4, half-maximal inhibitory concentration: 11600 nM
The estimate for compound 4 lay 1.5-fold (0.17 log units) above the measured number, within the range that was stated.
By their numbers in this assay, from the lowest: compounds 1, 2 and 4 (each within the scatter of the next). At a limit, above all of these: compound 3.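

Exchanging 6-fluoropyridin-3-yl for 2-fluoropyridin-3-yl gives an at least 1.7-fold lower number from compound 3 to compound 4 (0.23 log units; that floor lies within the scatter), so the isomer swap is not firmly shown to change the read-out at this position. Compound 3 stands at a limit of the assay and not at a number: the limit of > 20000 nM in this assay, at which 1 of the 4 values shown sits. With a 1.1-fold higher number from compound 2 to compound 4 (0.03 log units; within the scatter) and a 1.6-fold higher number from compound 1 to compound 4 (0.20 log units; within the scatter), 2-fluoropyridin-3-yl, 3-fluorophenyl and bromo are not told apart at this position.

From the compounds shown here alone, the true size of the isomer step stays open while compound 3 has only a limit. Also open, going by these compounds, is how an amine or a carboxylic acid on the aryl ring at this position would read.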